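The source may report more compounds than this note shows. Statements on the series, on what has been measured and on what is new or still open speak of the compounds shown alone.

Compound 1: `Cc1nc(N)sc1CCCN/C(N)=N/C(=O)N[C@H](C)c1ccccc1` — 0.34
Compound 2: `CCCNC(=O)/N=C(\N)NCCCc1sc(N)nc1C` — 0.32
Compound 3: `Cc1nc(N)sc1CCCN/C(N)=N/C(=O)Nc1ccccc1` — 0.25

In a functional assay on HEK293T cells for agonist activity at histamine H2 receptor (Homo sapiens), read by beta-arrestin recruitment (on this read-out lower numbers stand for smaller maximal responses and higher numbers for larger maximal responses), compound 3 gives 0.25, which sits at the lower end of the three numbers, though neither gap is meaningful: a number 0.070 lower from compound 2 to compound 3 (within the scatter) and a number 0.090 lower from compound 1 to compound 3 (within the scatter). Compound 4 is `CCCCCNC(=O)/N=C(\N)NCCCc1sc(N)nc1C`. Its difference from compound 3 is pentyl in place of phenyl on an amide-type nitrogen. Among the measured compounds shown here, two measured steps bear on this change. The step a number 0.070 lower from compound 2 to compound 3 (within the scatter) is the nearest comparison, since it exchanged an alkyl chain on the same amide-type nitrogen for the phenyl group; the step from compound 3 to compound 4 runs the other way, back to an alkyl chain, now two carbons longer. The step a number 0.090 lower from compound 1 to compound 3 (within the scatter) also replaced a carbon-bearing group with phenyl and stayed within scatter. The third step, a number 0.020 lower from compound 1 to compound 2 (within the scatter), shows that changing between two carbon-bearing groups on this nitrogen likewise moved little. The expected step a number 0.070 higher from compound 3 to compound 4 (within the scatter) is therefore small, at most a modest rise. Compound 4 is estimated to give 0.32, with a range from 0.2 to 0.45.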

Compound 4, intrinsic activity: the largest response reached, as a fraction of the reference agonist's: 0.15
Beside the measured number, compound 4's estimate is 0.17 above it; measured number below the stated range.
By their numbers in this assay, from the lowest: compounds 4, 3, 2 and 1 (each within the scatter of the next, the first and the last beyond it).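

Among the compounds shown here, in (this assay), the group on the amide-type nitrogen produces steps beyond the scatter for the first time. Lengthening propyl to pentyl gives a modest step (a number 0.17 lower from compound 2 to compound 4 (beyond the scatter)), and replacing 1-phenylethyl with pentyl gives another (a number 0.19 lower from compound 1 to compound 4 (beyond the scatter)), so these groups are not interchangeable at this position, whereas the exchange of phenyl for pentyl does not separate the two groups (a number 0.10 lower from compound 3 to compound 4 (within the scatter)). No measurement here explains these differences.

The compounds shown leave open whether the response changes steadily with chain length, since only propyl and pentyl can be compared and butyl or hexyl could show whether the trend holds. They also leave open how a benzyl group or a terminal amine on the chain would behave at this nitrogen.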